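This account rests on a few compounds, and the source may have more. Where it says the series, first, only, none or still open, it means among the compounds named here.

Measured in a functional assay on SH-SY5Y cells (Homo sapiens) for cytotoxicity, read by MTT assay, with a stated time of 72 h; on this read-out higher numbers stand for weaker inhibition and lower numbers for stronger inhibition:
- compound 1 `O=C1c2c[n+]([O-])c3ccccc3c2C(=O)c2c1c1ccccc1n2CCCCn1ccnc1` gives 130 nM
- compound 2 `CN1CCN(CCCCn2c3c(c4ccccc42)C(=O)c2c[n+]([O-])c4ccccc4c2C3=O)CC1` gives 100 nM

For the measured compounds named here, compound 2 sits within the scatter of compound 1, the only other compound measured. Compound 3 `O=C1c2c[n+]([O-])c3ccccc3c2C(=O)c2c1c1ccccc1n2CCN1CCCC1` has not yet been measured. Its difference from compound 2 is pyrrolidin-1-yl in place of 2-(4-methylpiperazin-1-yl)ethyl on a saturated chain carbon, two bonds along the chain from an aromatic nitrogen. The same difference, cut one bond further out, reads 4-(4-methylpiperazin-1-yl)butyl to 2-(pyrrolidin-1-yl)ethyl. Going by the values given here, only one measured step bears on this: a 1.3-fold lower number from compound 1 to compound 2 (0.11 log units; within the scatter), an exchange of 1H-imidazol-1-yl for 4-methylpiperazin-1-yl on the same chain. Among the compounds with values here, no measured step alters the chain or brings in pyrrolidin-1-yl, so the evidence is thin. With that single step as the guide, no change beyond the scatter is expected in this assay. The expected step is a 1.2-fold higher number from compound 2 to compound 3 (0.08 log units; within the scatter). For compound 3 the estimated value is 120 nM, with an expected range from 40 nM to 350 nM.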

Compound 3, half-maximal inhibitory concentration: 520 nM
Estimate against measurement, compound 3: 4.3-fold (0.64 log units) below; the whole stated range lies below it.
By their numbers in this assay, from the lowest: compounds 2 and 1 (each within the scatter of the next); then compound 3.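

In this assay, for the compounds shown here, this is the first change at this position to move the number beyond the scatter, and it moves it upward from both earlier compounds (a 5.2-fold higher number from compound 2 to compound 3 (0.72 log units; beyond the scatter); a 4.0-fold higher number from compound 1 to compound 3 (0.60 log units; beyond the scatter)). Exchanging the ring at the end of the butyl chain had not separated compound 1 from compound 2, whereas going to 2-(pyrrolidin-1-yl)ethyl alters the chain and the ring together, and this single change cannot say how much each part contributes. Nothing measured here accounts for the shift.

From the compounds shown here alone, it remains open whether 4-(pyrrolidin-1-yl)butyl would stay near compound 2 or 2-(4-methylpiperazin-1-yl)ethyl would fall near compound 3, which would separate the two parts of the change. Going by these compounds, how an open-chain dimethylamine or a morpholine at the end of the ethyl chain would read also remains open.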